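The source may report more compounds than this note shows. Statements on the series, on what has been measured and on what is new or still open speak of the compounds shown alone.

Of the compounds shown here, two built on a shared core have been tested in a functional assay on SW480 cells (Homo sapiens) for cytotoxicity, read by MTT assay, with a stated time of 4 days; a higher number here means a weaker inhibitor, a lower number a stronger inhibitor. Compound 1 has the structure `COc1ccc(-c2cn(C[C@H]3c4c(ccc(O)c4C)[C@@H]4CC[C@@]5(C)C[C@]43CC5=O)nn2)cc1`. In this assay compound 1 gives > 20000 nM, which is a limit of the assay rather than a number. Compound 2 has the structure `C=C1C[C@]23C[C@@]1(O)CC[C@@H]2c1cccc(C)c1[C@@H]3Cn1cc(-c2ccc(Br)cc2)nn1`. In this assay compound 2 gives > 20000 nM, again a limit rather than a number. Going by the values given here, both measured values therefore sit at the limit of > 20000 nM in this assay, at which 2 of the 2 values shown sit, so compound 2 stands where every value so far stands. Compound 3, with the structure `C=C1C[C@]23C[C@@]1(O)CC[C@@H]2c1cccc(C)c1[C@@H]3Cn1cc(-c2ccc(F)cc2)nn1`, has not yet been measured. It differs from compound 2 in one place: fluoro in place of bromo on an aromatic carbon. Among the compounds with values here, no step between two measured compounds exists to guide the size of this change. Because both values rest at the limit of > 20000 nM in this assay, at which 2 of the 2 values shown sit, no step beyond the scatter is expected in this assay. Compound 3 is expected to give 30000 nM, within 10000 nM to 100000 nM, most likely reported again as a limit. The expected step that the limit leaves unreadable from compound 2 to compound 3 is estimated to lie within the scatter.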

Compound 3, half-maximal inhibitory concentration: > 20000 nM
Compound 3 was reported as a limit; the forecaster's own chance of this, stated with the estimate: 80%; the middle value is on the limit's open side.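

In this assay compound 3 gives > 20000 nM, which is a limit and not a number. Compound 2 also sits at a limit, so no step can be read between compound 2 and compound 3. The compounds shown leave open whether fluoro in place of bromo makes any difference to cytotoxicity.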